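The source may hold more compounds than are shown below. What is called first, only, known or untested is meant among the compounds shown, and "the series" means these compounds.

Values in a functional assay on the whole organism (blood) with Rattus norvegicus as the target, with stated times of 24 h and 1 h, at a dose of 5 mg/kg by the intraperitoneal route; on this read-out higher numbers stand for a stronger effect at the one dose given and lower numbers for a weaker effect:
compound 1, `O=C(NC1CCCCC1)NS(=O)(=O)N1CCC(CCNC(=O)c2ccnc3ccccc23)CC1`: 16%
compound 2, `COc1ccc2nccc(C(=O)NCCC3CCN(S(=O)(=O)NC(=O)NC[C@@H]4C[C@@H]5C=C[C@@H]4C5)CC3)c2c1`: 10%
compound 3, `COc1ncccc1C(=O)NCCC1CCN(S(=O)(=O)NC(=O)NC[C@H]2C[C@@H]3C=C[C@@H]2C3)CC1`: 20%

Compound 3 gives the highest of the three numbers, with compound 1 nearest and compound 2 furthest, yet both gaps stay within the usual scatter, so no ranking of the three is supported. Compound 4, `CCOCCNC(=O)NS(=O)(=O)N1CCC(CCNC(=O)c2cccnc2OC)CC1`, differs from compound 3 by a group of 4 heavy atoms (3 carbon, 1 oxygen; no ring) in place of a group of 7 heavy atoms (7 carbon; 2 five-membered non-aromatic rings of carbon only), on a saturated chain carbon bound to an amide-type nitrogen. Among the measured compounds shown here, no step between two measured compounds is at hand to gauge a change of this kind, and the three measured numbers sit close together. The expected step in this assay is a number 5 percentage points lower from compound 3 to compound 4 (within the scatter), that is, none beyond the scatter. For compound 4 the estimate in this assay is 15%, within 4% to 30%.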

Compound 4, a percentage reported as activity, at one dose (the size of the read-out at that dose, not a potency): 7%
Estimate against measurement, compound 4: 8 percentage points above, and the stated range covers the measured number.
By their numbers in this assay, from the lowest: compounds 4, 2, 1 and 3 (each within the scatter of the next, the first and the last beyond it).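

In this assay, among the compounds shown here, ethoxymethyl in place of the group of 7 heavy atoms with 2 five-membered non-aromatic rings gives a number 13 percentage points lower from compound 3 to compound 4 (beyond the scatter), the first step that can be read at this position. A saturated chain carbon bound to an amide-type nitrogen is thus a place where the substituent can change the read-out, though this rests on a single pair. Nothing measured here accounts for the step. Still open, from the compounds shown here alone, is whether losing the rings or gaining the oxygen of ethoxymethyl matters more. Going by these compounds, how an amine, a carboxylic acid or a longer carbon chain would read at this position also remains open.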